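This account rests on a few compounds, and the source may have more. Where it says the series, first, only, none or still open, it means among the compounds named here.

Measured so far in a functional assay on HeLa S3 cells (Homo sapiens) for antiproliferative activity, read by XTT assay, with a stated time of 72 h; on this read-out lower numbers stand for stronger inhibition and higher numbers for weaker inhibition:

- compound 1, `COc1ncnc2c1c(-c1ccoc1)cn2[C@@H]1O[C@H](CO)[C@@H](O)[C@H]1O`: in this assay compound 1 gives 1790 nM.
- compound 2, `COc1nc(N)nc2c1c(-c1ccoc1)cn2[C@@H]1O[C@H](CO)[C@@H](O)[C@H]1O`: in this assay compound 2 reaches only the limit of the assay, > 20000 nM.
- compound 3, `O=c1[nH]cnc2c1c(-c1cc3ccccc3o1)cn2[C@@H]1O[C@H](CO)[C@@H](O)[C@H]1O`: in this assay compound 3 likewise reaches only a limit, > 20000 nM.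

Compounds 1 and 2 share a core and differ in one place: amino in place of hydrogen on an aromatic carbon. That change gives an at least 11-fold higher number from compound 1 to compound 2 (1.04 log units; beyond the scatter). The step is bounded only on one side, since compound 2 sits at the limit of > 20000 nM in this assay, at which 2 of the 3 values shown sit.

Compound 4, `Nc1nc2c(c(-c3cc4ccccc4o3)cn2[C@@H]2O[C@H](CO)[C@@H](O)[C@H]2O)c(=O)[nH]1`, is not yet measured. It stands to compound 3 as compound 2 stands to compound 1: amino in place of hydrogen on an aromatic carbon. The surroundings of the place are not word for word the same, as the new group in compound 4 is meta to a group of 1 heavy atom, whereas in compound 2 it is meta to a methoxy group (2 heavy atoms); so this is the same kind of change, not the same change. How the core of compound 3 differs from the core of compound 1 is not broken down here.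

For compound 4 the step expected in this assay is a step that the limit leaves unreadable from compound 3 to compound 4, resting on the weakening seen from compound 1 to compound 2 and on the fact that compound 3 already gives only a limit, > 20000 nM. The value estimated for compound 4 in this assay is therefore 40000 nM, within a range of 15000 nM to 150000 nM, most likely reported again only as a limit.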

Compound 4, half-maximal inhibitory concentration: > 20000 nM
Compound 4: only a limit was reported; the forecaster's own chance of this, stated with the estimate: 90%; the middle value does not contradict the limit.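

No step can be read from compound 3 to compound 4 in this assay, because both compounds give only a limit, and the same one: the limit of > 20000 nM in this assay, at which 3 of the 4 values shown sit.

The compounds shown leave open whether amino in place of hydrogen on an aromatic carbon changes activity at all on the core of compound 3, as any such change lies hidden beyond the limit of this read-out.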